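Removing a methyl group: cytotoxicity of four pyrazole amines

This account rests on a few compounds, and the source may have more. Where it says the series, first, only, none or still open, it means among the compounds named here.

Compound 1 `FC(F)(F)c1ccc(NCc2cn(-c3ccccc3)nc2-c2ccccc2)cc1`, compound 2 `Cc1ccc(-c2nn(-c3ccccc3)cc2CNc2ccc(C(F)(F)F)cc2)cc1` and compound 3 `Cc1ccc(NCc2cn(-c3ccccc3)nc2-c2ccc(Br)cc2)cc1` were tested in an ADME assay on Vero 76 cells (Chlorocebus sabaeus) for cytotoxicity, read by MTT assay, with a stated time of 96 h; a higher number here means that more compound is tolerated, a lower number that less compound is tolerated. In this assay compound 1 gives 17000 nM and compound 2 gives 45000 nM. Compound 3 reaches only the limit of this assay, > 100000 nM. The difference between the cores of compound 2 and compound 3 is not broken down here. Going from compound 2 to compound 1 makes one change, (hydrogen in place of methyl on an aromatic carbon), and this step gave a 2.6-fold lower number from compound 2 to compound 1 (0.42 log units; beyond the scatter). Compound 4 `Brc1ccc(-c2nn(-c3ccccc3)cc2CNc2ccccc2)cc1` has not yet been measured; it differs from compound 3 by the same kind of change, (hydrogen in place of methyl on an aromatic carbon). From compound 3 to compound 4 a step of about an at least 1.1-fold lower number from compound 3 to compound 4 (0.04 log units; that floor lies within the scatter) is expected, resting on the measured step from compound 2 to compound 1, so compound 4 is estimated at roughly 90000 nM, within 30000 nM to 300000 nM.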

Compound 4, half-maximal cytotoxic concentration: 52000 nM
Compound 4: the middle estimate sits 1.7-fold (0.24 log units) above what was measured, and the stated range covers the measured number.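

Removing the methyl group from a second core gave an at least 1.9-fold lower number from compound 3 to compound 4 (0.28 log units; that floor lies within the scatter) in this assay, which agrees in direction with the earlier step but does not fix the size of this one: the same change on two cores in this assay, a 2.6-fold lower number (0.42 log units; beyond the scatter) from compound 2 to compound 1 and an at least 1.9-fold lower number (0.28 log units; that floor lies within the scatter) from compound 3 to compound 4; the limit leaves it open whether they differ

Compound 3 is held at a limit of the assay, not at a number: the limit of > 100000 nM in this assay, at which 1 of the 4 values shown sits.

The change therefore carries to the second core only as a tentative direction, not as a step of known size.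

The compounds shown leave open how the same change behaves on cores beyond these two. They also leave open what a group other than hydrogen, such as an amine or a carboxylic acid, would do in place of the methyl group.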